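Replacing 3,4,5-trimethoxyphenyl with 3-fluoro-4-methoxyphenyl in Compound 3

This account rests on a few compounds, and the source may have more. Where it says the series, first, only, none or still open, it means among the compounds named here.

In a functional assay on A549 cells (Homo sapiens) for antiproliferative activity, read by sulforhodamine B assay, with a stated time of 48 h (on this read-out lower numbers stand for stronger inhibition and higher numbers for weaker inhibition), compound 3 `COc1cc(OC)c2sc(-c3ccc(N/C=C\C(=O)c4cc(OC)c(OC)c(OC)c4)c(C)c3)nc2c1` gives 14400 nM. This sits level with compound 1 `COc1cc(OC)c2sc(-c3ccc(N/C=C\C(=O)c4ccc(OC)c(O)c4)c(C)c3)nc2c1` at 14300 nM, and both lie well above compound 2 `COc1ccc(C(=O)/C=C\Nc2ccc(-c3nc4cc(OC)c(OC)c(OC)c4s3)cc2C)cc1F` at 1690 nM. The next compound, compound 4 `COc1cc(OC)c2sc(-c3ccc(N/C=C\C(=O)c4ccc(OC)c(F)c4)c(C)c3)nc2c1`, keeps the core of compound 3 and alters only the group on the carbonyl carbon: 3-fluoro-4-methoxyphenyl in place of 3,4,5-trimethoxyphenyl on a carbonyl carbon.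

Among the compounds with values here, one measured step concerns this same place. Placing 3,4,5-trimethoxyphenyl where 3-hydroxy-4-methoxyphenyl stood gave a 1.0-fold higher number from compound 1 to compound 3 (0.00 log units; within the scatter), so that exchange left the number within the scatter. Within the data shown here, the same 3-fluoro-4-methoxyphenyl group as in compound 4 also occurs on a different core in the only other guide, compound 2, which gives 1690 nM. Among the measured compounds shown here, no measured pair isolates the effect of that group, so the low number of compound 2 cannot be credited to it alone. The flat step argues for little change, while compound 2 points toward a lower number, and this assay is therefore expected to show only a modest decrease. The estimated change is a 2.1-fold lower number from compound 3 to compound 4 (0.31 log units; beyond the scatter). For compound 4 the estimated value is 7000 nM, with an expected range of 2200 nM to 16000 nM.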

Compound 4, half-maximal inhibitory concentration: 15300 nM
For compound 4 the middle estimate is 2.2-fold (0.34 log units) below the measured one, and the stated range covers the measured number.
By their numbers in this assay, from the lowest: compound 2; then compounds 1, 3 and 4 (each within the scatter of the next).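

In this assay the exchange on the carbonyl carbon came to a 1.1-fold higher number from compound 3 to compound 4 (0.03 log units; within the scatter) and fluoro in place of hydroxy came to a 1.1-fold higher number from compound 1 to compound 4 (0.03 log units; within the scatter) so that 3-hydroxy-4-methoxyphenyl, 3,4,5-trimethoxyphenyl and 3-fluoro-4-methoxyphenyl now stand level on the shared core. Within the data shown here, with 3-fluoro-4-methoxyphenyl held constant, hydrogen in place of methoxy on an aromatic carbon of the core came to a 9.1-fold higher number from compound 2 to compound 4 (0.96 log units; beyond the scatter) and this is the first measured step to separate compound 2 from the others at a place other than the carbonyl carbon. The low number of compound 2 therefore goes with that methoxy on the core and not with 3-fluoro-4-methoxyphenyl, which gave no change by itself on the core of compound 3.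

On these data alone, what the other two groups on the carbonyl carbon would give on the core of compound 2 remains open. So does whether a different kind of group at this place, such as an amine or a carboxylic acid on the phenyl ring, would move the number at all. Nothing at hand explains why these groups stand level or why the methoxy on the core matters.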